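From oxan-4-yl to ethyl on an amide carbonyl

This account rests on a few compounds, and the source may have more. Where it says the series, first, only, none or still open, it means among the compounds named here.

Compound 1 `CCC(=O)N[C@@H](C)c1ccc(NC(=O)N2CC(c3cccnc3)C2)cc1` gives 120 nM
Compound 2 `C[C@H](NC(=O)C1CCOCC1)c1ccc(NC(=O)N2CC(c3cncc(N)c3)C2)cc1` gives 970 nM

In a functional assay on COR-L23 cells (Homo sapiens) for antiproliferative activity, read by CellTiter-Glo, with a stated time of 72 h (on this read-out higher numbers stand for weaker inhibition and lower numbers for stronger inhibition), compound 2 gives 970 nM as the higher of the two numbers, and its gap to compound 1 lies beyond the scatter. Compound 3 `CCC(=O)N[C@@H](C)c1ccc(NC(=O)N2CC(c3cncc(N)c3)C2)cc1` differs from compound 2 in one place, described by ethyl in place of oxan-4-yl on a carbonyl carbon and meaning ethyl in place of oxan-4-yl on a carbonyl carbon. Within the data shown here, no measured pair shows this change alone, so its size remains uncertain. The propanoylamino group of compound 3 also occurs in compound 1, which gives 120 nM despite differing elsewhere, so a lower number beyond the scatter is expected in this assay for this change. The estimated change is a 3.9-fold lower number from compound 2 to compound 3 (0.59 log units; beyond the scatter) and carries wide uncertainty. Compound 3 is estimated at 250 nM within an expected range from 70 nM to 800 nM in this measurement.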

Compound 3, half-maximal inhibitory concentration in the COR-L23 assay: 1580 nM
The estimate for compound 3 lay 6.3-fold (0.80 log units) below the measured number, outside the stated range (above it).
By their numbers in the COR-L23 assay, from the lowest: compound 1; then compounds 2 and 3 (each within the scatter of the next).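

Swapping oxan-4-yl for ethyl on the carbonyl carbon makes no clear difference in the COR-L23 assay, where compound 2 gives 970 nM and compound 3 gives 1580 nM, with a 1.6-fold higher number from compound 2 to compound 3 (0.21 log units; within the scatter), so this position accepts either group in this pair. Among these compounds, the large shift in the COR-L23 assay lies elsewhere: amino in place of hydrogen on an aromatic carbon gives a 13-fold higher number from compound 1 to compound 3 (1.12 log units; beyond the scatter), a change now seen on its own for the first time. In a physicochemical assay for solubility, read by LC-MS, in phosphate buffer, with a stated time of 24 h, at pH 6.8 (on this read-out lower numbers stand for lower solubility and higher numbers for higher solubility), compound 2 gives 440000 nM and compound 3 gives 230000 nM, so the oxan-4-yl to ethyl swap also stays within the scatter, with a 1.9-fold lower number from compound 2 to compound 3 (0.28 log units; within the scatter), and nothing measured here explains either result.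

As far as these compounds go, it remains open whether the amino step would be as large with oxan-4-yl on the carbonyl carbon. Also open, from the compounds shown here alone, is how a methyl or a fluorine in place of that amino group, or a longer chain or a carboxylic acid on the carbonyl carbon, would read.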